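A few compounds are considered here, and "the series" means these few. Any claim that something is new, unique, unknown or untested is made for them only; others in the source may bear on it.

Measured in a functional assay on NCI-H460 cells (Homo sapiens) for inhibition, read by sulforhodamine B assay, with a stated time of 48 h; a higher number here means a weaker inhibitor of growth, a lower number a stronger inhibitor of growth:
- compound 1 `CCOC(=O)c1nn(-c2ccccc2)c(-c2ccc([N+](=O)[O-])cc2)c1CNC(C)(C)C`: 429000 nM; 327000 nM (2 entries)
- compound 2 `CC(C)(C)NCc1c(C(=O)O)nn(-c2ccccc2)c1-c1ccc(Cl)cc1`: 70500 nM
- compound 3 `CC(C)(C)NCc1c(C(=O)O)nn(-c2ccccc2)c1-c1ccccc1`: > 716000 nM (a limit of the assay, not a number)

Compound 3 has no single number in this assay, and its entry stands only as the limit > 716000 nM. Compound 4 `CC(C)(C)NCc1c(C(=O)O)nn(-c2ccccc2)c1-c1ccc([N+](=O)[O-])cc1` departs from compound 3 in one place, with nitro in place of hydrogen on an aromatic carbon, para to a large group: nitro in place of hydrogen on an aromatic carbon.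

The closest measured step is hydrogen in place of chloro on an aromatic carbon, which gave an at least 10-fold higher number from compound 2 to compound 3 (1.00 log units; beyond the scatter). Read in reverse, this pair links a group on that ring with a lower number, but it is a single pair, and chloro is not nitro. Compound 1 also carries 4-nitrophenyl, on a core that is not the same, and compound 1 gives 429000 nM; 327000 nM (2 entries).

A step towards a lower number in this assay is therefore expected, meaning stronger inhibition of growth, though probably smaller than the step seen with chloro. The expected change is an at least 3.9-fold lower number from compound 3 to compound 4 (0.59 log units; beyond the scatter). For compound 4 the estimated value is 180000 nM, with an expected range from 50000 nM to 600000 nM.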

Compound 4, concentration for 50% growth inhibition: > 634000 nM
Compound 4 was reported as a limit (the forecaster's own chance of this, stated with the estimate: 25%); middle value at least 3.5-fold (0.54 log units) away from the limit.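

In this assay compound 4 is a limit of the assay and not a number: the limit of > 634000 nM in this assay, at which 1 of the 4 values shown sits. The step to it from the phenyl compound 3 cannot be read, because compound 3 is also a limit: the limit of > 716000 nM in this assay, at which 1 of the 4 values shown sits. What this position does show is that the groups placed on it are not interchangeable: nitro in place of chloro gives an at least 8.9-fold higher number from compound 2 to compound 4 (0.95 log units; beyond the scatter), so the lower number seen with chloro did not carry over to 4-nitrophenyl on the shared core.

As far as these compounds go, whether nitro lowers the number at all relative to hydrogen remains open, and so does whether a methoxy group or fluorine in the same place would behave like chloro or like nitro. Also open, from the compounds shown here alone, is how the carboxylic acid of compound 4 truly compares with the ethyl ester of compound 1. In this assay compound 1 gives 429000 nM; 327000 nM (2 entries). Only a limit stands on the acid side.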